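Moving the pyrazole attachment point on the amide nitrogen

A few compounds are considered here, and "the series" means these few. Any claim that something is new, unique, unknown or untested is made for them only; others in the source may bear on it.

Measured in an assay on HEK293 cells for agonist activity at transient receptor potential cation channel subfamily M member 8 (Homo sapiens), read by fluorescence and calcium flux, with a stated time of 15 min; a higher number here means that more compound is needed for the effect, a lower number that less compound is needed:
compound 1 `Cc1ccc(OCC(=O)N(O)Cc2cccs2)cc1` gives 8000 nM
compound 2 `Cc1ccc(OCC(=O)N(Cc2cccs2)c2ccn[nH]2)cc1` gives 0.2 nM

Compound 2 stands lowest of the two numbers in this assay; its nearest neighbour is compound 1, and the one step shown, a 40000-fold lower number from compound 1 to compound 2 (4.60 log units; beyond the scatter), is large and lies well beyond the scatter. That step replaces a hydroxy group on the amide-type nitrogen with 1H-pyrazol-5-yl.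

Compound 3 `Cc1ccc(OCC(=O)N(Cc2cccs2)c2cn[nH]c2)cc1` keeps every atom of compound 2 but joins them differently: 1H-pyrazol-4-yl in place of 1H-pyrazol-5-yl on an amide-type nitrogen. Going by the values given here, no measured step changes the attachment point of the pyrazole, so the only step that bears on the question, from compound 1 to compound 2, tells how much the pyrazole itself matters, not how its orientation matters. Given that the shape of the group is altered while its donor and acceptor are kept, a moderate rise in the number is expected, though with wide uncertainty. The expected step is then a 10-fold higher number from compound 2 to compound 3 (1.00 log units; beyond the scatter). In this assay compound 3 is expected to give about 2 nM, with a range from 0.2 nM to 30 nM.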

Compound 3, half-maximal effective concentration: 1.4 nM
Compound 3: middle estimate off by 1.4-fold (0.15 log units), on the high side, within the range that was stated.
By their numbers in this assay, from the lowest: compound 2; then compound 3; then compound 1.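

In this assay, the point at which the pyrazole joins the amide-type nitrogen proves to matter on its own, though modestly: with the atoms of the group unchanged and its counted donor and acceptor the same, moving from 1H-pyrazol-5-yl to 1H-pyrazol-4-yl gives a 7.0-fold higher number from compound 2 to compound 3 (0.85 log units; beyond the scatter) and this shift lies beyond the scatter. Most of the gain over the hydroxy group survives the move, as 1H-pyrazol-4-yl in place of hydroxy still gives a 5700-fold lower number from compound 1 to compound 3 (3.76 log units; beyond the scatter) and this step remains large. So the earlier step from the hydroxy group is no longer tied to a single attachment point, although 1H-pyrazol-5-yl keeps the lower number of the two. No supporting measurement is available to explain the difference between the two pyrazole attachments.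

The compounds shown leave open whether the large gain requires a pyrazole at all, or whether an imidazole, a 1,2,3-triazole or a plain phenyl ring on the same nitrogen would give a similar number. They also leave open how a methyl group on the pyrazole ring would alter the number for either attachment.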